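Swapping cyano for dimethylcarbamoyl on a clearance scale

A few compounds are considered here, and "the series" means these few. Any claim that something is new, unique, unknown or untested is made for them only; others in the source may bear on it.

In an ADME assay (liver) for metabolic stability, with Liver microsome (Homo sapiens) as the target, using microsomes (on this read-out higher numbers stand for fast clearance and lower numbers for slow clearance), compound 1 `Cc1ccc(Oc2cc(C(=O)Nc3cnc(C)cn3)cc3oc(C)cc23)cc1` gives 47 mL/min/kg as its number, compound 2 `Cc1cnc(NC(=O)c2cc(Oc3ccc(S(C)(=O)=O)cc3)c3cc(C)oc3c2)cn1` gives 13 mL/min/kg and compound 3 `Cc1cnc(NC(=O)c2cc(Oc3ccc(C#N)cc3)c3cc(C)oc3c2)cn1` gives 29 mL/min/kg on the same scale. Compound 3 is not the lowest of the three: the closest comparison is a 1.6-fold lower number from compound 1 to compound 3 (0.21 log units; within the scatter) and the furthest is a 2.2-fold higher number from compound 2 to compound 3 (0.35 log units; beyond the scatter) here. For the measured compounds named here, compound 4 `Cc1cnc(NC(=O)c2cc(Oc3ccc(C(=O)N(C)C)cc3)c3cc(C)oc3c2)cn1` has dimethylcarbamoyl in place of cyano on an aromatic carbon and no measured compound carries that group. Exchanges at this same place gave a 3.6-fold lower number from compound 1 to compound 2 (0.56 log units; beyond the scatter) as their largest step, so a bigger move is possible, but without a direct precedent only a small fall is expected in this assay and none beyond the scatter. The estimated change is a 1.3-fold lower number from compound 3 to compound 4 (0.10 log units; within the scatter) in this picture. For compound 4 the expected clearance is 23 mL/min/kg (range 11 mL/min/kg to 45 mL/min/kg).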

Compound 4, clearance: 17 mL/min/kg
Compound 4: the middle estimate sits 1.4-fold (0.13 log units) above what was measured; the measured number falls inside the stated range.
By their numbers in this assay, from the lowest: compounds 2, 4, 3 and 1 (each within the scatter of the next, the first and the last beyond it).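

With five heavy atoms in place of two, dimethylcarbamoyl leaves the clearance in this assay within the scatter of both other polar-looking neighbours: a 1.7-fold lower number from compound 3 to compound 4 (0.23 log units; within the scatter) and a 1.3-fold higher number from compound 2 to compound 4 (0.12 log units; within the scatter). Only the comparison with the methyl group goes beyond the scatter, a 2.8-fold lower number from compound 1 to compound 4 (0.44 log units; beyond the scatter), so compound 4 joins compound 2 in standing clear of compound 1, which compound 3 does not. Nothing shown here gives a reason for these differences. Going by these compounds, whether a carboxylic acid, an amine or a primary carboxamide at this place would read alike stays open.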